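Methoxy walk on the aryl ring of the coumarin series

This account rests on a few compounds, and the source may have more. Where it says the series, first, only, none or still open, it means among the compounds named here.

Measured so far:
compound 1 `COc1ccc(-c2cc3cc(C4C(C#N)=C(N)OC5=C4C(=O)CC(C)(C)C5)cc(C(C)C)c3oc2=O)cc1`: 64.9%
compound 2 `COc1ccc(-c2cc3cc(C4C(C#N)=C(N)OC5=C4C(=O)CC(C)(C)C5)cc(C(C)C)c3oc2=O)cc1OC`: 86.6%
compound 3 `COc1ccc(-c2cc3cc(C4C(C#N)=C(N)OC5=C4C(=O)CCC5)cc(C(C)(C)C)c3oc2=O)cc1OC`: -16.6%

All three values come from a functional assay on the whole organism (strain Swiss albino) with Mus musculus as the target, in the forced swim test, with a stated time of 5 min, at a dose of 0.5 mg/kg by the intraperitoneal route; on this read-out lower numbers stand for less inhibition and higher numbers for more inhibition at the one dose given (going by the name of the read-out). Compound 3 stands lowest of the three, and its gaps to compound 1 and compound 2 are both beyond the scatter. How the core of compound 1 and the core of compound 3 differ is not broken down here.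

From compound 1 to compound 2 the change is methoxy in place of hydrogen on an aromatic carbon, and it brought a number 21.7 percentage points higher from compound 1 to compound 2 (beyond the scatter).

Compound 4 `COc1cc(-c2cc3cc(C4C(C#N)=C(N)OC5=C4C(=O)CCC5)cc(C(C)(C)C)c3oc2=O)cc(OC)c1OC` is not yet measured. It differs from compound 3 by methoxy in place of hydrogen on an aromatic carbon, the same kind of change as from compound 1 to compound 2, though the surroundings are not identical: in compound 4 the entering methoxy is also meta to a methoxy group.

Carrying over the one comparable step, a rise of about the same size is expected, a number 24.6 percentage points higher from compound 3 to compound 4 (beyond the scatter), resting on the single step from compound 1 to compound 2 and on the low value of compound 3 -16.6%. Among the compounds with values here, the estimate for compound 4 in this assay is 8%, with a range from -20% to 40%, wide since only one precedent exists.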

Compound 4, a percentage reported as inhibition, in the whole organism at one dose (the size of the read-out at that dose, not a potency): 5.33%
The estimate for compound 4 lay 2.7 percentage points above the measured number; measured number inside the range.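

In this assay, going from 3,4-dimethoxyphenyl to 3,4,5-trimethoxyphenyl gave a number 21.9 percentage points higher from compound 3 to compound 4 (beyond the scatter), so methoxy in place of hydrogen on an aromatic carbon has now been read on two cores and the size of the step carried over: the same change on two cores in this assay, a number 21.7 percentage points higher (beyond the scatter) from compound 1 to compound 2 and a number 21.9 percentage points higher (beyond the scatter) from compound 3 to compound 4, 0.2 percentage points apart, within the scatter of two such steps This holds even though the two steps start from different aryl rings, with the entering methoxy in compound 4 ortho to a methoxy group and meta to a methoxy group. It does not show why the step keeps its size, two steps make no rule for a further core, and the gap between the cores themselves stays unresolved, as compound 1 and compound 3 differ in more than one place.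

The compounds shown carry only methoxy groups on this aryl ring, so it remains open whether ethoxy, a hydroxyl group, fluorine or an amine on that aromatic carbon would move the read-out by a similar amount. From the compounds shown here alone, each reading also comes from a single dose, so whether the step holds at other doses remains open too.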